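Notes on the chloro to fluoro swap in compound 1

The source may report more compounds than this note shows. Statements on the series, on what has been measured and on what is new or still open speak of the compounds shown alone.

Measured in a functional assay on U-251 cells (Homo sapiens) for antiproliferative activity; a higher number here means a weaker inhibitor of growth, a lower number a stronger inhibitor of growth:
- compound 1 `Cc1cnc2[nH]c(-c3cccc(Cl)c3)cc(=O)c2c1`: 69.2 nM
- compound 2 `Cc1ccnc2nc(-c3ccc4ccccc4c3)cc(O)c12`: 646 nM
- compound 3 `Cc1ccc2c(O)cc(-c3ccc4ccccc4c3)nc2n1`: 4570 nM

Compound 1 holds the lowest number of the three, and the gaps up to compound 2 and compound 3 both lie beyond the scatter. Within the data shown here, compound 2 and compound 3 differ from compound 1 in more than one place, so the series offers no measured single-place step to calibrate against. Among the measured compounds shown here, their values show only that the number can move widely across these structures.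

Compound 4 `Cc1cnc2[nH]c(-c3cccc(F)c3)cc(=O)c2c1` has not yet been measured. Its difference from compound 1 is a single exchange: fluoro in place of chloro on an aromatic carbon. In words, this is fluoro in place of chloro on an aromatic carbon, meta to a large group, with the rest of the structure unchanged.

For the measured compounds named here, no measured pair shows what this exchange does in this assay, so the expectation is weakly grounded. It starts from compound 1 at 69.2 nM and assumes a small move toward a higher number, possibly none beyond the scatter. The expected step is a 1.7-fold higher number from compound 1 to compound 4 (0.24 log units; within the scatter). For compound 4 the estimated value is 120 nM, with an expected range of 35 nM to 400 nM.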

Compound 4, concentration for 50% growth inhibition: 40.7 nM
Compound 4: the middle estimate sits 2.9-fold (0.47 log units) above what was measured; the measured number falls inside the stated range.
By their numbers in this assay, from the lowest: compounds 4 and 1 (each within the scatter of the next); then compound 2; then compound 3.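

In this assay, among these compounds, the exchange of chloro for fluoro gives the first single-place step: a 1.7-fold lower number from compound 1 to compound 4 (0.23 log units; within the scatter). On this aromatic carbon, meta to a large group, the two halogens therefore cannot be told apart by this read-out, and the core of compound 1 keeps its growth inhibition with either one in place. This is a single pair, so it describes this one exchange on this one core and sets no rule for the series, and nothing measured here bears on why the two numbers read alike.

The compounds shown carry only these two halogens at this position, so it remains open whether the same carbon would accept a group of a different kind, such as methoxy, an amine or a carboxylic acid, or simply hydrogen in place of the halogen. On these data alone, it also remains open whether fluoro in place of chloro would read the same way at another carbon of that ring, or on the structures of compound 2 and compound 3.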